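The source may report more compounds than this note shows. Statements on the series, on what has been measured and on what is new or still open speak of the compounds shown alone.

In an ADME assay on V79 cells (Cricetulus griseus) for cytotoxicity, read by MTT assay, with a stated time of 72 h (on this read-out lower numbers stand for stronger inhibition and higher numbers for weaker inhibition), compound 1 `COc1ccc(Nc2nnnn2-c2ccc(Cl)cc2)cc1` gives 115000 nM. Compound 2 `COc1ccc(-n2nnnc2Nc2ccc(Br)cc2)cc1` stands within the scatter of that value at 212000 nM. Compound 3 `COc1ccc(-n2nnnc2Nc2ccc(Cl)cc2)cc1` stands beyond the scatter of that value, with the higher number at 245000 nM. The next structure, compound 4 `COc1ccc(Nc2nnnn2-c2cccc(Cl)c2)cc1`, keeps the atoms of compound 1 but carries 3-chlorophenyl in place of 4-chlorophenyl on an aromatic nitrogen. Going by the values given here, no measured step makes this same change. Among the compounds with values here, the only measured step, a 1.2-fold higher number from compound 2 to compound 3 (0.06 log units; within the scatter), puts chloro in place of bromo and bears on it only loosely, so no shift beyond the scatter is expected. The expected size is a 1.2-fold higher number from compound 1 to compound 4 (0.09 log units; within the scatter). For compound 4 the estimated value is 140000 nM, with an expected range of 70000 nM to 280000 nM.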

Compound 4, half-maximal inhibitory concentration: 124000 nM
Beside the measured number, compound 4's estimate is 1.1-fold (0.05 log units) above it; the measured number falls inside the stated range.
By their numbers in this assay, from the lowest: compounds 1, 4, 2 and 3 (each within the scatter of the next, the first and the last beyond it).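

Putting 3-chlorophenyl in place of 4-chlorophenyl on the aromatic nitrogen gives a 1.1-fold higher number from compound 1 to compound 4 (0.03 log units; within the scatter) in this assay, so this position takes either chlorophenyl with no difference that stands clear of the scatter. The earlier step exchanged only bromo and chloro, and it left the placing of the halogen on the ring untouched. Nothing available here explains the closeness of these two numbers.

Still open, as far as these compounds go, is whether an amine or a carboxylic acid in place of the chloro on this phenyl would stay equally close to compound 1.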